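A few compounds are considered here, and "the series" means these few. Any claim that something is new, unique, unknown or untested is made for them only; others in the source may bear on it.

Three related compounds have been measured in a physicochemical assay for solubility, measured as kinetic solubility (a lower number here means a less soluble compound, a higher number a more soluble compound), and they give a first idea of the range for this series. Compound 1 (`CNc1nccc(N2CC[C@H](NC(=O)Nc3ccc(CN(C)C)c(C(F)(F)F)c3)C2)n1`) gives 102000 nM, the top reading of the three, although compound 2 (`CNc1nccc(N2CC[C@H](NC(=O)Nc3ccc(OC(F)(F)F)cc3)C2)n1`), at 70400 nM, lies within the usual scatter of it. That leaves compound 1 level with compound 2 rather than clearly ahead. Compound 3 (`Nc1nccc(N2CC[C@H](NC(=O)Nc3ccc(Cl)c(C(F)(F)F)c3)C2)n1`) gives 30300 nM, a lower number than compound 1 and one beyond the scatter.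

The next compound to be measured is compound 4 (`CNc1nccc(N2CC[C@H](NC(=O)Nc3ccc(CN4CCN(C)CC4)c(C(F)(F)F)c3)C2)n1`), which is compound 1 with a single change: 4-methylpiperazin-1-yl in place of dimethylamino on a saturated chain carbon bound to an aromatic carbon. In words, 4-methylpiperazin-1-yl stands in place of dimethylamino on a saturated chain carbon bound to an aromatic carbon. No two measured compounds differ in only one place, so the data hold no direct precedent for this swap and give no reason to expect a move in either direction. The best starting point is therefore compound 1 itself, at 102000 nM. The expected step of a 1.1-fold lower number from compound 1 to compound 4 (0.03 log units; within the scatter) is small and should stay within the scatter. For compound 4 the estimated value in this assay is 95000 nM, with an expected range from 45000 nM to 190000 nM.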

Compound 4, solubility: 67500 nM
For compound 4 the middle estimate is 1.4-fold (0.15 log units) above the measured one, within the range that was stated.
By their numbers in this assay, from the lowest: compound 3; then compounds 4, 2 and 1 (each within the scatter of the next).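

Among the compounds shown here, replacing dimethylamino with 4-methylpiperazin-1-yl on a saturated chain carbon bound to an aromatic carbon gives a 1.5-fold lower number from compound 1 to compound 4 (0.18 log units; within the scatter) in this assay and provides the first comparison where only one place differs. At this position, the larger group, which brings in a six-membered non-aromatic ring with 2 hetero atoms, leaves the reading level with that of compound 1. This single pair shows that the change is tolerated in this measurement, but nothing available explains the result.

One step at one position cannot show how the reading would respond to other groups on the same chain carbon, such as morpholin-4-yl, a carboxylic acid or a longer chain ending in an amine. It also leaves open whether the same swap would give a similar result when another part of the core of compound 1 is different, since the other compounds shown differ from it in more than one place.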